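From Cyclopentylamino to Cyclohexylamino: One Expected Step

The compounds below may be only part of what the source reports. "The series", "measured", "known", "first", "only" and "open" are said of these compounds alone.

Compound 1 `CC1(C)CC(=O)c2cc(C#N)c(NCc3ccccc3)nc2C1` in an in vitro functional assay on cells for antagonist activity at metabotropic glutamate receptor 1 (Rattus norvegicus), read by inositol phosphate accumulation; on this read-out lower numbers stand for stronger inhibition and higher numbers for weaker inhibition: 2500 nM
Compound 2 `CN(Cc1ccccc1)c1nc2c(cc1C#N)C(=O)CC(C)(C)C2` in this assay: 5300 nM
Compound 3 `CC1(C)CC(=O)c2cc(C#N)c(NC3CCCC3)nc2C1` in this assay: 78 nM

Among the three measured compounds, compound 3 stands lowest, and its steps to the two others are both beyond the scatter. Going the other way, the step of a 32-fold lower number from compound 1 to compound 3 (1.51 log units; beyond the scatter) is large, while the step of a 2.1-fold higher number from compound 1 to compound 2 (0.33 log units; beyond the scatter) is only modest. The group carried on the ring nitrogen thus moves the number strongly in one measured pair.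

Compound 4 `CC1(C)CC(=O)c2cc(C#N)c(NC3CCCCC3)nc2C1` differs from compound 3 in one place: cyclohexyl in place of cyclopentyl on a nitrogen on an aromatic ring. Going by the values given here, no measured pair shows this change itself. The large step of a 32-fold lower number from compound 1 to compound 3 (1.51 log units; beyond the scatter) is the only one on the same nitrogen, and it compares a benzyl with a saturated ring, not two saturated rings of neighbouring size. On that basis compound 4 is expected to stay near compound 3, with a step of a 1.2-fold lower number from compound 3 to compound 4 (0.08 log units; within the scatter) that is not beyond the scatter. The estimate for compound 4 in this assay is 65 nM, expected to fall between 15 nM and 300 nM.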

Compound 4, half-maximal inhibitory concentration: 4000 nM
Compound 4: middle estimate off by 62-fold (1.79 log units), on the low side; the whole stated range lies below it.
By their numbers in this assay, from the lowest: compound 3; then compounds 1, 4 and 2 (each within the scatter of the next, the first and the last beyond it).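

On the nitrogen on an aromatic ring, adding to the saturated ring is not a neutral change: cyclohexyl in place of cyclopentyl, in this assay, gives a large loss (a 51-fold higher number from compound 3 to compound 4 (1.71 log units; beyond the scatter)). The earlier compounds shown here could be read as favouring a saturated ring over benzyl, but compound 4 goes against that reading, since cyclohexyl and benzyl do not separate (a 1.6-fold higher number from compound 1 to compound 4 (0.20 log units; within the scatter)). Among the compounds shown, the low number therefore belongs to cyclopentyl alone, and nothing available here accounts for the size of this step.

The compounds shown leave open whether the number rises as steeply with a smaller ring such as cyclobutyl. They also leave open how an open chain such as isopropyl on the same nitrogen would compare with cyclopentyl.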